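Moving a Nitro Group on a Low-Toxicity Scaffold

The compounds below may be only part of what the source reports. "The series", "measured", "known", "first", "only" and "open" are said of these compounds alone.

Of the compounds shown here, three built on closely related cores have been tested in an ADME assay on HPLF cells (Homo sapiens) for cytotoxicity, with a stated time of 24 h; on this read-out higher numbers stand for lower toxicity in this test and lower numbers for higher toxicity in this test. Compound 1 `CN(C)c1ccc(/C=C2\CCC/C(=C\c3cccc([N+](=O)[O-])c3)C2=O)cc1` is one of them. In this assay compound 1 reaches only a limit of the test, > 400000 nM. Compound 3 `CN(C)c1ccc(/C=C2\CCC/C(=C\c3ccc([N+](=O)[O-])cc3)C2=O)cc1` differs from compound 1 in a single place: 4-nitrophenyl in place of 3-nitrophenyl on a double-bonded chain carbon bound to a double-bonded ring carbon. In this assay compound 3 also reaches only a limit, > 400000 nM. The step that the two limits leave unreadable from compound 1 to compound 3 therefore has no readable size, because the limit of > 400000 nM in this assay, at which 3 of the 3 values shown sit, covers both ends of it. Compound 2 `COc1cc(/C=C2\CCC/C(=C\c3cccc([N+](=O)[O-])c3)C2=O)cc(OC)c1OC` sits on a different core; how the two cores differ is not broken down here. In this assay compound 2 likewise gives only a limit, > 400000 nM.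

Compound 4 `COc1cc(/C=C2\CCC/C(=C\c3ccc([N+](=O)[O-])cc3)C2=O)cc(OC)c1OC` has not yet been measured. It stands to compound 2 exactly as compound 3 stands to compound 1, through the same change: 4-nitrophenyl in place of 3-nitrophenyl on a double-bonded chain carbon bound to a double-bonded ring carbon. Since every measured compound sits at the limit, the measured pair cannot show whether this change moves cytotoxicity at all. Compound 4 is expected to show 400000 nM in this assay, with a likely range from 150000 nM to 1000000 nM. The expected step is a number no higher from compound 2 to compound 4 (the limit leaves the size open), meaning no measurable shift is anticipated. This expectation rests on (the limit of > 400000 nM in this assay, at which 3 of the 3 values shown sit), which places all shown values at the same ceiling, so compound 4 is most likely to return only a limit as well.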

Compound 4, half-maximal cytotoxic concentration: 378000 nM
Compound 4: the middle estimate sits 1.1-fold (0.02 log units) above what was measured; low and high end bracket the measured number.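

The new step reads an at least 1.0-fold lower number from compound 2 to compound 4 (0.02 log units; that floor lies within the scatter) in this assay when 4-nitrophenyl takes the place of 3-nitrophenyl on a double-bonded chain carbon bound to a double-bonded ring carbon, so on the core of compound 2 this change gives no shift that can be told apart from the scatter. Going by these compounds, that figure is only a floor, since one end of the step is a limit of the test and not a number, and the true size of the step stays open. The same change on the core of compound 1 cannot be read either, so nothing here shows whether the change acts alike on the two cores, and this one pair gives no rule that can be carried from core to core: the limit of > 400000 nM in this assay, at which 3 of the 4 values shown sit.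

The compounds shown all carry a nitro group on that ring, so what a carboxylic acid or a nitrile in its place would do to the read-out remains open on both cores. On these data alone, it also remains open whether any change at this place can bring the number well clear of the limit, which a comparison between the two cores would need.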